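A few compounds are considered here, and "the series" means these few. Any claim that something is new, unique, unknown or untested is made for them only; others in the source may bear on it.

Measured in a physicochemical assay for permeability, using PAMPA; on this read-out higher numbers stand for higher permeability and lower numbers for lower permeability:
- compound 1 `Cc1ccc([C@@H](C)Oc2cc3oc(=O)n(CCC(=O)O)c3cc2Cl)nc1`: 22 nm/s
- compound 2 `CCc1cc2oc(=O)n(CCC(=O)O)c2cc1Cl`: < 10 nm/s (a limit)
- compound 3 `COc1cc2oc(=O)n(CCC(=O)O)c2cc1Cl`: < 3 nm/s (a limit)

Compound 3 has no number in this assay, only the limit < 3 nm/s. Compound 2 is also known only as a limit, < 10 nm/s. Compound 1 is the only one of the three with a number.

The next compound is compound 4 `C[C@@H](Oc1cc2oc(=O)n(CCC(=O)O)c2cc1Cl)c1ncco1`, which differs from compound 3 on an oxygen on an aromatic ring: a group of 7 heavy atoms (5 carbon, 1 nitrogen, 1 oxygen; one five-membered aromatic ring with 2 hetero atoms) in place of one carbon atom, on an oxygen on an aromatic ring. The methyl is replaced by a group of 7 heavy atoms that holds one five-membered aromatic ring with 2 hetero atoms.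

Within the data shown here, the only measured step is a step that the two limits leave unreadable from compound 2 to compound 3. It involves a different change and gives no size to carry over. The closest guide is compound 1, which also has a ring-bearing group on that oxygen and gives 22 nm/s, so a rise is expected for compound 4 on that single comparison. The expected step is an at least 3.3-fold higher number from compound 3 to compound 4 (0.52 log units; beyond the scatter), upward, though its size is poorly fixed and a result at a limit remains possible.

For compound 4 the estimate is 10 nm/s, with an expected range of 3 nm/s to 30 nm/s.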

Compound 4, apparent permeability: < 3 nm/s
Compound 4 ended at the assay's limit; the forecaster's own chance of this, stated with the estimate: 35%; at least 3.3-fold (0.52 log units) between middle value and limit.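

In this assay compound 4 is known only as a limit, < 3 nm/s. Exchanging 5-methylpyridin-2-yl for 1,3-oxazol-2-yl on the saturated chain carbon gives an at least 7.3-fold lower number from compound 1 to compound 4 (0.86 log units; beyond the scatter), so on this single pair the read-out at this position depends on which ring is present, and a ring-bearing group on the oxygen does not by itself secure a measurable number. The steps to compound 4 from compound 2 and from compound 3 join two limits and cannot be read.

Still open, as far as these compounds go, is whether the difference rests on the ring itself or on the methyl of the 5-methylpyridin-2-yl group, a question that a plain phenyl or an unsubstituted pyridin-2-yl on the same chain carbon would bear on. From the compounds shown here alone, the full size of the drop also stays unknown, as does the reading of the opposite stereoisomer at that chain carbon.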